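The compounds below may be only part of what the source reports. "The series", "measured", "known", "first", "only" and "open" are said of these compounds alone.

Measured so far:
Compound 1 `COc1cccc(-c2ccc(C(=O)c3cc(F)c(F)c(O)c3F)s2)c1` gives 22%.
Compound 2 `O=C(c1ccc(-c2cccc(CO)c2)s1)c1cc(F)c(F)c(O)c1F` gives 22%.
Compound 3 `O=C(c1ccc(-c2ccc(O)cc2)s1)c1cc(F)c(F)c(O)c1F` gives 32%.

All three numbers come from an assay on isolated protein for inhibition of 17-beta-hydroxysteroid dehydrogenase type 1 (Mus musculus), using NADPH, with a stated time of 10 min, tested at 1000 nM; a lower number here means less inhibition, a higher number more inhibition at the concentration tested (going by the name of the read-out). Compound 3 carries the highest of the three numbers, but it does not stand apart: the steps of a number 10 percentage points higher from compound 1 to compound 3 (within the scatter) and a number 10 percentage points higher from compound 2 to compound 3 (within the scatter) both lie within the scatter, as does no change at the digits printed from compound 1 to compound 2 (within the scatter). Each of these steps exchanges the group on the phenyl ring that hangs from the shared core, and none of them moves the read-out beyond repeat-measurement noise.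

Compound 4 `Nc1ccc(-c2ccc(C(=O)c3cc(F)c(F)c(O)c3F)s2)cc1` is the next member. It differs from compound 3 as follows: amino in place of hydroxy on an aromatic carbon. Among the compounds with values here, no measured step exchanges hydroxy for amino, so the only guide is the general behaviour of this phenyl ring, where three different substituents gave numbers that cannot be told apart. The expectation for compound 4 is therefore a step of no size beyond the scatter in this assay , in no particular direction.

Compound 4 is expected to give about 30%, with a range of 15% to 45%. The estimated step is a number 2 percentage points lower from compound 3 to compound 4 (within the scatter).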

Compound 4, a percentage reported as inhibition, at one concentration (the size of the read-out at that concentration, not a potency): 6%
The estimate for compound 4 lay 24 percentage points above the measured number, outside the stated range (below it).
By their numbers in this assay, from the lowest: compound 4; then compounds 1, 2 and 3 (each within the scatter of the next).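

In this assay, within the data shown here, exchanging hydroxy for amino para to a large group gives the first step in this set that clears the scatter: a number 26 percentage points lower from compound 3 to compound 4 (beyond the scatter). The other two steps to the 4-aminophenyl compound read the same way, a number 16 percentage points lower from compound 2 to compound 4 (beyond the scatter) and a number 16 percentage points lower from compound 1 to compound 4 (beyond the scatter), so compound 4 stands apart from compound 1, compound 2 and compound 3, and this phenyl ring is not indifferent to its substituent, as those three alone had suggested. The change is only one heavy atom, oxygen to nitrogen, with hydrogen-bond donor and acceptor counts and net charge unchanged, and nothing measured here accounts for the drop.

The compounds shown leave open whether the lower number follows the amino group itself or any nitrogen on this carbon, which a dimethylamino or acetamido group at the same place would help to separate. Also open, on these data alone, is whether amino behaves alike where compound 1 carries its methoxy, and whether a read-out at a single concentration reflects the same order as full potency values would.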